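Aryl ketone variation in an ethyl carbamate piperazine series

The source may hold more compounds than are shown below. What is called first, only, known or untested is meant among the compounds shown, and "the series" means these compounds.

Measured so far:
compound 1 `CCCCCCCCC(=O)c1ccc(OCCCN2CCN(C(=O)OCC)CC2)cc1`: 2690 nM
compound 2 `CCOC(=O)N1CCN(CCCOc2ccc(C(=O)c3ccc(F)cc3)cc2)CC1`: 42700 nM

In an assay on isolated protein for binding affinity to histamine H2 receptor (Homo sapiens) (a lower number here means a stronger inhibitor, a higher number a weaker inhibitor), compound 2 gives 42700 nM and stands highest of the two numbers; the nearest is compound 1, which gives 2690 nM. Going by the values given here, the only step measured, a 16-fold higher number from compound 1 to compound 2 (1.20 log units; beyond the scatter), swaps an octyl chain for an aryl group on the carbonyl carbon and is large. Compound 3 `CCOC(=O)N1CCN(CCCOc2ccc(C(=O)c3cccc(C)c3)cc2)CC1` differs from compound 2 by 3-methylphenyl in place of 4-fluorophenyl on a carbonyl carbon. Among the compounds with values here, no measured step exchanges one aryl group for another, so the step from compound 1 to compound 2 bears on this change only loosely, as a sign that what sits on the carbonyl carbon can move the number strongly. Within the data shown here, with no direct precedent, the change from compound 2 to compound 3 is expected to be small, within the scatter or a little beyond it, with no firm direction. The expected step is a 1.4-fold lower number from compound 2 to compound 3 (0.15 log units; within the scatter). Compound 3 is therefore estimated at 30000 nM, with a range from 8000 nM to 110000 nM.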

Compound 3, inhibition constant: 3720 nM
For compound 3 the middle estimate is 8.1-fold (0.91 log units) above the measured one; the whole stated range lies above it.
By their numbers in this assay, from the lowest: compounds 1 and 3 (each within the scatter of the next); then compound 2.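

In this assay, one aryl group cannot stand in for another on this carbonyl carbon: 3-methylphenyl in place of 4-fluorophenyl gives an 11-fold lower number from compound 2 to compound 3 (1.06 log units; beyond the scatter) and counts as a large step. Replacing octyl with 3-methylphenyl gives a 1.4-fold higher number from compound 1 to compound 3 (0.14 log units; within the scatter) and stays within the scatter, so the earlier 16-fold higher number from compound 1 to compound 2 (1.20 log units; beyond the scatter) reflects 4-fluorophenyl in particular and not the exchange of octyl for any aryl group. Nothing measured here speaks to what separates the two aryl groups.

The compounds shown leave open whether the gap between compound 2 and compound 3 follows the loss of the fluorine or the gain of the methyl, and plain phenyl on the carbonyl carbon would give the reference for both. Also open, on these data alone, is how a shorter chain such as butyl compares with octyl at this place.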